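This account rests on a few compounds, and the source may have more. Where it says the series, first, only, none or still open, it means among the compounds named here.

Measured in a functional assay on DU-145 cells (Homo sapiens) for inhibition, read by trypan blue exclusion, with a stated time of 96 h; a lower number here means a stronger inhibitor of growth, a higher number a weaker inhibitor of growth:
- Compound 1 `Cc1ccc(S/C(=C/c2ccc(Br)cc2)C(=O)c2ccc(Cl)cc2)cc1`: 25000 nM
- Compound 2 `Cc1ccc(S/C(=C/c2sccc2C)C(=O)c2ccc(Br)cc2)cc1`: 50000 nM
- Compound 3 `Cc1ccc(S/C(=C/c2ccc(N(C)C)cc2)C(=O)c2ccc(Cl)cc2)cc1`: > 100000 nM, a limit

Compound 3 stands at the limit of > 100000 nM in this assay, at which 1 of the 3 values shown sits, so it has only a limit and no number. Compound 4 `Cc1ccc(S/C(=C/c2sccc2C)C(=O)c2ccc(Cl)cc2)cc1`, not yet measured, differs from it by 3-methylthiophen-2-yl in place of 4-(dimethylamino)phenyl on a double-bonded chain carbon bound to a double-bonded chain carbon. For the measured compounds named here, the one measured step that bears on this is an at least 4.0-fold higher number from compound 1 to compound 3 (0.60 log units; beyond the scatter), and it removes a ring without the dimethylamino group from the comparison. Compound 2 carries the same 3-methylthiophen-2-yl and gives 50000 nM. On that value, a modest step towards a lower number is expected in this assay, estimated as an at least 2.2-fold lower number from compound 3 to compound 4 (0.34 log units; beyond the scatter). For compound 4 the estimate is 45000 nM, with an expected range of 18000 nM to 100000 nM.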

Compound 4, concentration for 50% growth inhibition: 50000 nM
Compound 4: the middle estimate sits 1.1-fold (0.05 log units) below what was measured; the range from low to high includes it.
By their numbers in this assay, from the lowest: compounds 1, 2 and 4 (each within the scatter of the next). At a limit, above all of these: compound 3.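

In this assay, 3-methylthiophen-2-yl in place of 4-(dimethylamino)phenyl on a double-bonded chain carbon gives an at least 2.0-fold lower number from compound 3 to compound 4 (0.30 log units; that floor lies within the scatter), a step that rests on a limit for compound 3: the limit of > 100000 nM in this assay, at which 1 of the 4 values shown sits. Chloro in place of bromo on an aromatic carbon gives no change at the digits printed from compound 2 to compound 4 (within the scatter). 3-Methylthiophen-2-yl in place of 4-bromophenyl gives a 2.0-fold higher number from compound 1 to compound 4 (0.30 log units; within the scatter), so at this place only 4-(dimethylamino)phenyl stands apart among the groups shown.

Going by these compounds, whether a primary amine or a methoxy group on that phenyl ring would behave like dimethylamino or like bromo stays open.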